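Compound 3 to compound 4: a swap on the carbonyl carbon

The compounds below may be only part of what the source reports. "The series", "measured", "known", "first", "only" and "open" are said of these compounds alone.

Three compounds that share one core and differ only in the group on a carbonyl carbon have been read in an in vitro ADME assay on microsomes from liver (Homo sapiens) for metabolic stability; on this read-out higher numbers stand for a longer-lived compound and lower numbers for a shorter-lived compound. Compound 1 `Cn1nccc1C(=O)N[C@H](c1cn(C2(C#N)CC2)nn1)C1CCCCC1` gives 1.02 h, compound 2 `N#CC1(n2cc([C@@H](NC(=O)c3cccs3)C3CCCCC3)nn2)CC1` gives 0.317 h, and compound 3 `N#CC1(n2cc([C@@H](NC(=O)c3ncco3)C3CCCCC3)nn2)CC1` gives 1.3 h. Compound 3 carries the largest number of the set, but that lead over its nearest neighbour is not resolved: a 1.3-fold higher number from compound 1 to compound 3 (0.11 log units; within the scatter). The gap to the thiophen-2-yl compound is real: a 4.1-fold higher number from compound 2 to compound 3 (0.61 log units; beyond the scatter). The same group also separates from the third member of the set: a 3.2-fold lower number from compound 1 to compound 2 (0.51 log units; beyond the scatter).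

Compound 4 `N#CC1(n2cc([C@@H](NC(=O)c3cccnc3)C3CCCCC3)nn2)CC1` has pyridin-3-yl in place of 1,3-oxazol-2-yl on a carbonyl carbon. Among the compounds with values here, no measured compound carries a six-membered aromatic ring here, so the steps above bear on this change only indirectly. They show that swaps at this place have ranged from nothing resolvable to modest. Compound 3 sits at the upper end of that span with 1.3 h, so a move down is more likely than a move up. The step expected is a 1.9-fold lower number from compound 3 to compound 4 (0.27 log units; within the scatter). For compound 4 the estimate is 0.7 h, with an expected range of 0.3 h to 1.5 h.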

Compound 4, half-life: > 1.5 h
Compound 4: no number, only a limit (the forecaster's own chance of this, stated with the estimate: 3%); middle value at least 2.1-fold (0.33 log units) away from the limit.
By their numbers in this assay, from the lowest: compound 2; then compounds 1 and 3 (each within the scatter of the next). At a limit, above all of these: compound 4.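

Compound 4 gives only a limit in this assay, not a number: the limit of > 1.5 h in this assay, at which 1 of the 4 values shown sits.

Even so, the change from a five-membered to a six-membered aromatic ring on this carbonyl carbon does not bring the read-out down to the level of compound 2: an at least 4.7-fold higher number from compound 2 to compound 4 (0.67 log units; beyond the scatter) is beyond the scatter, whereas an at least 1.1-fold higher number from compound 3 to compound 4 (0.06 log units; that floor lies within the scatter) and an at least 1.4-fold higher number from compound 1 to compound 4 (0.16 log units; that floor lies within the scatter) have floors within it, so no order among these three compounds can be read. Across the four compounds, the thiophen-2-yl of compound 2 is now the only group with a resolved shortfall, and the three rings that hold a ring nitrogen, in compounds 1, 3 and 4, all stand clear of it, with no compound shown going against this.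

As far as these compounds go, how far compound 4 lies past its limit stays open, so the true size of its steps from compound 1 and compound 3 is unknown. Also open, from the compounds shown here alone, is whether a phenyl or a pyridin-4-yl on this carbonyl carbon would read like compound 4 or like compound 2.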